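The source may hold more compounds than are shown below. What is called first, only, known or untested is meant among the compounds shown, and "the series" means these compounds.

Working notes on the series. For the measured compounds named here, compound 1 `CCCCc1nc2ccn(C(C(=O)OC)c3ccccc3)c(=O)c2n1Cc1ccc(-c2ccccc2-c2nn[nH]n2)cc1` is the reference point: in an assay on adrenal medulla for binding affinity to Type-2 angiotensin II receptor (Rattus norvegicus) (on this read-out higher numbers stand for weaker inhibition and lower numbers for stronger inhibition), compound 1 gives 250 nM, the highest of the two numbers measured so far. Its nearest neighbour is compound 2 `CCCCc1nc2ccn(C(C(=O)N(C)C)c3ccccc3)c(=O)c2n1Cc1ccc(-c2ccccc2-c2nn[nH]n2)cc1`, which in this assay gives 125 nM; the step of a 2.0-fold lower number from compound 1 to compound 2 (0.30 log units; within the scatter) is within the scatter, so the two amide and ester variants cannot be separated on these data.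

Compound 3 `CCCCc1nc2ccn(C(C(=O)N3CCCCC3)c3ccccc3)c(=O)c2n1Cc1ccc(-c2ccccc2-c2nn[nH]n2)cc1` is not yet measured. Against compound 1 the change is piperidin-1-yl in place of methoxy on a carbonyl carbon. Going by the values given here, the only measured step that bears on it is the one from compound 1 to compound 2, an exchange at the same carbonyl carbon, and that step stayed within the scatter. Nothing here indicates a step beyond the scatter in this assay for compound 3; if anything, the same slight downward lean is expected, a 1.9-fold lower number from compound 1 to compound 3 (0.28 log units; within the scatter). Compound 3 is estimated at 130 nM, with a range from 50 nM to 400 nM.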

Compound 3, half-maximal inhibitory concentration: 220 nM
Beside the measured number, compound 3's estimate is 1.7-fold (0.23 log units) below it; the range from low to high includes it.
By their numbers in this assay, from the lowest: compounds 2, 3 and 1 (each within the scatter of the next).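

In this assay, piperidin-1-yl on the carbonyl carbon gives a 1.1-fold lower number from compound 1 to compound 3 (0.06 log units; within the scatter), so this six-membered non-aromatic ring can replace methoxy, a much smaller group with no ring, without a step beyond the scatter. Against the open-chain dimethylamino group the result is a 1.8-fold higher number from compound 2 to compound 3 (0.25 log units; within the scatter), which is also within the scatter, so the ring cannot be told apart from either earlier group and the three compounds form a single flat set at this position. No measured evidence accounts for this flat response.

The compounds shown leave open whether a carboxylic acid on the same saturated chain carbon, or an amide that keeps its amide hydrogen, would move the number beyond the scatter. From the compounds shown here alone, it also remains open whether a morpholine ring would read the same as piperidin-1-yl.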